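Swapping a Small Ring Amine for a Larger One

The source may hold more compounds than are shown below. What is called first, only, known or untested is meant among the compounds shown, and "the series" means these compounds.

Compound 1 `Cn1c(-c2ccc(NC(=O)CN3CCCC3)cc2)nc2cc(C(F)(F)F)ccc21` is the starting point. In an ADME assay on Vero cells (Chlorocebus sabaeus) for cytotoxicity (on this read-out higher numbers stand for lower toxicity in this test and lower numbers for higher toxicity in this test), compound 1 gives only a limit of the assay, > 100000 nM. Among the compounds with values here, its close relative compound 2 `Cn1c(-c2ccc(N)cc2)nc2cc(C(F)(F)F)ccc21` is the only other compound measured here. In this assay compound 2 likewise gives only a limit, > 100000 nM. The step that the two limits leave unreadable from compound 1 to compound 2 therefore cannot be read, since both values sit (the limit of > 100000 nM in this assay, at which 2 of the 2 values shown sit). The new compound 3 `Cn1c(-c2ccc(NC(=O)CN3CCN(c4ccccc4)CC3)cc2)nc2cc(C(F)(F)F)ccc21` carries 4-phenylpiperazin-1-yl in place of pyrrolidin-1-yl on a saturated chain carbon bound to a carbonyl carbon. Within the data shown here, no measured step bears directly on this exchange, and the single comparison available, from compound 1 to compound 2, is unreadable in size. The expectation therefore rests on both measured compounds resting at the limit, and no step beyond the scatter is foreseen. Compound 3 is expected to show a number no higher from compound 1 to compound 3 (the limit leaves the size open). Compound 3 is estimated at 100000 nM in this assay, with a range from 30000 nM to 300000 nM.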

Compound 3, half-maximal cytotoxic concentration: 30000 nM
The estimate for compound 3 lay 3.3-fold (0.52 log units) above the measured number; the measured number falls inside the stated range.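

Exchanging pyrrolidin-1-yl for 4-phenylpiperazin-1-yl on a saturated chain carbon bound to a carbonyl carbon gives an at least 3.3-fold lower number from compound 1 to compound 3 (0.52 log units; beyond the scatter), so in this assay this position is not silent to a change of ring amine. On these data alone, because compound 1 rests at a limit, that step fixes only a minimum and its full size stays open. Compound 3 is also the only compound shown with a readable number, and the other two rest at the same limit: the limit of > 100000 nM in this assay, at which 2 of the 3 values shown sit.

The compounds shown leave open whether the six-membered ring with its second nitrogen or the added phenyl ring goes with the lower number. A 4-methylpiperazin-1-yl group, which keeps the ring and carries a methyl in place of the phenyl, would help to separate the two.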